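The source may hold more compounds than are shown below. What is called first, only, known or untested is meant among the compounds shown, and "the series" means these compounds.

Compound 1 `Clc1ccc2c(NCc3ncc[nH]3)ccnc2c1` gives 2.39 in a physicochemical assay for lipophilicity, measured as octanol-water partition, at pH 7.4; on this read-out higher numbers stand for higher lipophilicity and lower numbers for lower lipophilicity. Compound 2 `Clc1ccc2c(NCc3ncc(CN4CCCC4)[nH]3)ccnc2c1` carries (pyrrolidin-1-yl)methyl in place of hydrogen on an aromatic carbon and gives 1.42 in this assay, so that a number 0.97 log units lower from compound 1 to compound 2 (beyond the scatter). Compound 3 `Clc1ccc2c(NCc3nc(-c4ccccc4)cs3)ccnc2c1` gives 5.15 in this assay; the difference between its core and the core of compound 1 is not broken down here. Compound 4 `Clc1ccc2c(NCc3nc(-c4ccccc4)c(CN4CCCC4)s3)ccnc2c1` has not been measured; it carries (pyrrolidin-1-yl)methyl in place of hydrogen on an aromatic carbon, the same kind of change as before, but in compound 2 the group sits on a ring with 2 nitrogen, next to the ring nitrogen, whereas in compound 4 it sits on a ring with 1 nitrogen and 1 sulfur, next to the ring sulfur and next to the ring atom that bears a phenyl group. The step is expected to be a number 0.95 log units lower from compound 3 to compound 4 (beyond the scatter), resting on compound 2 because a number 0.97 log units lower from compound 1 to compound 2 (beyond the scatter). Compound 4 is therefore expected to give 4.2, likely between 3.6 and 4.8.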

Compound 4, distribution coefficient: 6.01
Beside the measured number, compound 4's estimate is 1.81 log units below it, outside the stated range (above it).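

In this assay, the same change, (pyrrolidin-1-yl)methyl in place of hydrogen on an aromatic carbon, gives a number 0.86 log units higher from compound 3 to compound 4 (beyond the scatter) but gave a number 0.97 log units lower from compound 1 to compound 2 (beyond the scatter) on the other core, so neither the size nor the direction of the step carried over. Going by these compounds alone, with a single pair on each core, this shows only that the step is not fixed across these two cores, and it sets no rule for any other core. Nothing available here accounts for the opposite directions.

As far as these compounds go, it remains open how a piperidine or morpholine in place of the pyrrolidine would behave on each core. Also open, from the compounds shown here alone, is whether a longer chain to the amine would change the direction of the step.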